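This account rests on a few compounds, and the source may have more. Where it says the series, first, only, none or still open, it means among the compounds named here.

Compounds measured so far:
compound 1, `C[C@H](NC(=O)CN(c1nc(Cl)nc2[nH]cnc12)C1CC1)C(=O)OCc1ccccc1`, which in a functional assay on the whole organism (Tail, strain ICR) with Mus musculus as the target, in the tail flick test, with a stated time of 120 min, at a dose of 25 umol/kg by the oral route (a lower number here means a weaker effect, a higher number a stronger effect of the compound at the dose given), gives 36.1%
compound 2, `CC[C@H](C)[C@H](NC(=O)CN(c1nc(Cl)nc2[nH]cnc12)C1CC1)C(=O)O`, which in this assay gives 21.4%
compound 3, `CC[C@H](C)[C@H](NC(=O)CN(c1nc(Cl)nc2[nH]cnc12)C1CC1)C(=O)OCc1ccccc1`, which in this assay gives 22%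

Compound 2 holds the lowest of the three numbers. Its nearest neighbour is compound 3, and the two lie within the scatter of each other, as the step of a number 0.6 percentage points higher from compound 2 to compound 3 (within the scatter) shows, so no order can be read between them. Compound 1 stands further off, with its value beyond the scatter from that of compound 2.

The compound still to be measured is compound 4, `NC(=O)CC[C@H](NC(=O)CN(c1nc(Cl)nc2[nH]cnc12)C1CC1)C(=O)O`. It differs from compound 2 at one place: 2-carbamoylethyl in place of sec-butyl on a saturated chain carbon bound to an amide-type nitrogen and a carbonyl carbon. The group that enters carries one hydrogen-bond donor and one hydrogen-bond acceptor, where the sec-butyl that leaves carries none.

Of the measured steps, only a number 14.1 percentage points lower from compound 1 to compound 3 (beyond the scatter) touches the same saturated chain carbon, and there the exchange ran from methyl to sec-butyl with a modest loss. Going by the values given here, no measured step introduces a carbamoyl-bearing chain at that place, so the direction of the change from sec-butyl to 2-carbamoylethyl has no precedent here. The step of a number 0.6 percentage points higher from compound 2 to compound 3 (within the scatter) concerns the oxygen next to the carbonyl and does not bear on this position.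

On this basis compound 4 is expected to sit close to compound 2, with a step of a number 0.6 percentage points higher from compound 2 to compound 4 (within the scatter) expected, inside the scatter. The estimate for compound 4 is 22%, ranging from 8% to 38%.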

Compound 4, a percentage reported as activity, at one dose (the size of the read-out at that dose, not a potency): 17.8%
Compound 4: the middle estimate sits 4.2 percentage points above what was measured; measured number inside the range.
By their numbers in this assay, from the lowest: compounds 4, 2 and 3 (each within the scatter of the next); then compound 1.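

In this assay, the step of a number 3.6 percentage points lower from compound 2 to compound 4 (within the scatter) shows that, with the carboxylic acid kept, 2-carbamoylethyl in place of sec-butyl on the saturated chain carbon bound to an amide-type nitrogen and a carbonyl carbon gives no difference that can be read. Until now this place had been probed only among the benzyl esters, in the step of a number 14.1 percentage points lower from compound 1 to compound 3 (beyond the scatter), so this is its first exchange among the free acids and the first to bring in a chain with a hydrogen-bond donor and acceptor, which here leaves the read-out unmoved beyond the scatter. Nothing available explains this result or the contrast with the step among the benzyl esters.

The compounds shown leave open whether the benzyl ester of compound 4, or the free acid matching compound 1 with its methyl, would follow the same pattern, so the effect of this chain cannot yet be separated from that of the ester. They also leave open how a primary amine or a carboxylic acid at the end of this chain, or a longer chain, would read at this place.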